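The source may report more compounds than this note shows. Statements on the series, on what has been measured and on what is new or still open speak of the compounds shown alone.

Measured compounds in a functional assay on BGC-823 cells (Homo sapiens) for antiproliferative activity, read by MTT assay, tested at 1 uM; on this read-out lower numbers stand for a weaker effect and higher numbers for a stronger effect at the one concentration tested:

compound 1 `COc1cc(C(=O)N/N=C/c2cccc(F)c2)cc(OC)c1OC`: 13.6%
compound 2 `COc1cc(C(=O)N/N=C/c2cccc(C(F)(F)F)c2)cc(OC)c1OC`: 17.7%

Compound 1 stands at the foot of the two numbers shown, but the single step available, a number 4.1 percentage points higher from compound 1 to compound 2 (within the scatter), is within the scatter, so neither compound can be called the stronger in this assay; compound 2 gives 17.7% and compound 1 gives 13.6%, and the two read as one level.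

Compound 3 `COc1cc(C(=O)N/N=C/c2ccc(F)cc2)cc(OC)c1OC` has not been measured in this assay. It differs from compound 1 by 4-fluorophenyl in place of 3-fluorophenyl on a carbon with a double bond to nitrogen. No measured step moves the fluorine from one ring position to another, so nothing bears directly on this change; the only step shown, the one from compound 1 to compound 2, swaps the group itself rather than its position and still stayed within the scatter. The series gives no ground to expect a step beyond the scatter here, and the expected change is a number 1.4 percentage points higher from compound 1 to compound 3 (within the scatter). Compound 3 is therefore estimated at 15% in this assay, with a range from 5% to 28%.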

Compound 3, a percentage reported as inhibition, at one concentration (the size of the read-out at that concentration, not a potency): 50.9%
Beside the measured number, compound 3's estimate is 35.9 percentage points below it, and the stated range ends below it.
By their numbers in this assay, from the lowest: compounds 1 and 2 (each within the scatter of the next); then compound 3.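

Replacing 3-fluorophenyl with 4-fluorophenyl on the carbon with a double bond to nitrogen leaves the atoms unchanged, yet in this assay it gives a number 37.3 percentage points higher from compound 1 to compound 3 (beyond the scatter), so the arrangement of the same atoms at this place can strongly change the read-out. Going by these compounds alone, the earlier step, a number 4.1 percentage points higher from compound 1 to compound 2 (within the scatter), exchanged fluoro for trifluoromethyl without changing the ring position and did not separate the two compounds, so the series now contains a positional change that registers beyond the scatter, whereas its one change of group did not. The compounds shown give no measurement that bears on why the position matters, and the difference stands only as an observation.

From the compounds shown here alone, it remains open whether this gain depends on fluorine itself or would also appear with another group in the same ring position, such as 4-chlorophenyl, 4-methoxyphenyl or 4-aminophenyl, and 2-fluorophenyl would complete the fluorine positional set. Also open, going by these compounds, is whether the step between these two isomers would hold as a difference in potency, since the read-out here is taken at a single concentration in one cell line.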